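This account rests on a few compounds, and the source may have more. Where it says the series, first, only, none or still open, it means among the compounds named here.

Among the compounds with values here, in an ADME assay on Vero cells (Chlorocebus sabaeus) for antiproliferative activity, read by MTT assay (a higher number here means a weaker inhibitor, a lower number a stronger inhibitor), compound 1 (`COc1ccc(-c2nc(N3CCNCC3)nc3ccccc23)c(OC)c1`) gives 50 ug/mL, the higher of the two numbers measured so far. Compound 2 (`c1ccc2c(c1)ccn2-c1nc(N2CCNCC2)nc2ccccc12`) gives 8.9 ug/mL, a lower number by more than the usual scatter, so compound 1 is the weaker inhibitor of this pair. Compound 3 (`COc1ccc(-c2nc(N3CCN(C)CC3)nc3ccccc23)c(OC)c1`) keeps the core of compound 1 and differs from it in one place: methyl in place of hydrogen on an amine nitrogen in a ring. This puts methyl in place of hydrogen on an amine nitrogen in a ring, turning piperazin-1-yl into 4-methylpiperazin-1-yl. Within the data shown here, no measured pair yet shows what this change does, so any expectation is uncertain. The expected step is a 1.3-fold lower number from compound 1 to compound 3 (0.10 log units; within the scatter), a slightly lower number that stays within the scatter. In this assay, the estimated value for compound 3 is 40 ug/mL, with an expected range from 15 ug/mL to 100 ug/mL.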

Compound 3, half-maximal inhibitory concentration: 50 ug/mL
Beside the measured number, compound 3's estimate is 1.3-fold (0.10 log units) below it; the range from low to high includes it.
By their numbers in this assay, from the lowest: compound 2; then compounds 1 and 3 (each within the scatter of the next).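

In this assay, methyl in place of hydrogen on the amine nitrogen in the ring gives no change at the digits printed from compound 1 to compound 3 (within the scatter), and this pair is the only one so far that isolates this change. On the core of compound 1, then, the hydrogen on this nitrogen can be replaced by a methyl with no effect that this assay can detect, so a free hydrogen at this position does not appear to be required for the reading here. Nothing measured here explains why the number holds steady.

Going by these compounds, it remains open whether a larger group on this nitrogen, such as an ethyl, an acetyl or a longer chain, would also leave the number unchanged. On these data alone, it is also open whether the same methyl would behave alike in compound 2, which gives 8.9 ug/mL.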